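A few compounds are considered here, and "the series" means these few. Any claim that something is new, unique, unknown or untested is made for them only; others in the source may bear on it.

Of the compounds shown here, three share one core and have been measured in an assay on cells for inhibition of alkaline phosphatase, tissue-nonspecific isozyme (Homo sapiens), read by luminescence, with stated times of 7 min and 20 min; a higher number here means a weaker inhibitor, a lower number a stronger inhibitor. Compound 1 `CN(C)CCNc1nn2c(=O)cc(C(F)(F)F)nc2s1` gives 450 nM there, the lowest number of the three. Among the measured compounds shown here, compound 2 `CCCCN(CCCC)c1nn2c(=O)cc(C(F)(F)F)nc2s1` gives 1530 nM in this assay, and compound 3 `COc1cc(OC)cc(-c2nn3c(=O)cc(C(F)(F)F)nc3s2)c1` gives 1150 nM; both of these steps from compound 1 lie beyond the scatter of the method, so compound 1 is the strongest inhibitor of the three so far.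

Compound 4 `O=c1cc(C(F)(F)F)nc2sc(-c3ccccc3F)nn12` has not yet been measured. It differs from compound 1 in one respect: 2-fluorophenyl in place of (2-(dimethylamino)ethyl)amino on an aromatic carbon. For the measured compounds named here, no measured pair in the set reproduces this exact change, so the expectation rests on compound 3, the only other member that carries an aromatic ring in the same place and whose value in this assay is 1150 nM. On that basis compound 4 is expected to be a weaker inhibitor than compound 1, with a step of a 2.7-fold higher number from compound 1 to compound 4 (0.43 log units; beyond the scatter) that goes beyond the scatter. The estimate for compound 4 in this assay is 1200 nM, with a range from 400 nM to 4000 nM.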

Compound 4, half-maximal inhibitory concentration: > 100000 nM
Compound 4: a limit, no number (the forecaster's own chance of this, stated with the estimate: 10%); middle value at least 83-fold (1.92 log units) from the limit.
By their numbers in this assay, from the lowest: compound 1; then compounds 3 and 2 (each within the scatter of the next). At a limit, above all of these: compound 4.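

Replacing (2-(dimethylamino)ethyl)amino with 2-fluorophenyl on this aromatic carbon gives an at least 220-fold higher number from compound 1 to compound 4 (2.34 log units; beyond the scatter), so the group at this place can decide whether inhibition is read at all in this assay. Compound 4 stands at a limit, not at a number: the limit of > 100000 nM in this assay, at which 1 of the 4 values shown sits. Compound 3 also carries an aromatic ring at this place and gives 1150 nM, so an aromatic ring there does not by itself remove measurable inhibition.

The compounds shown leave open whether a plain phenyl ring, without the fluorine, would read like compound 3 or like compound 4. They also leave open whether a primary amine or a shorter chain ending in a dimethylamino group at this place would keep the value of compound 1.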